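This account rests on a few compounds, and the source may have more. Where it says the series, first, only, none or still open, it means among the compounds named here.

Within the data shown here, only two compounds with this shared core have numbers so far in an ADME assay on L6 cells (Rattus norvegicus) for cytotoxicity; on this read-out lower numbers stand for stronger inhibition and higher numbers for weaker inhibition. Compound 1 `Cc1nc(-c2ccccn2)nc(NCc2ccccc2)c1Cl` gives 70100 nM, and compound 2 `Cc1nc(-c2ccccn2)nc(N2CCC(c3ccccc3)C2)c1Cl` gives 133000 nM. These two values lie within the usual scatter of repeated measurements, so this assay cannot tell compound 2 apart from compound 1.

Compound 3 `Cc1nc(-c2ccccn2)nc(N2CCC(Cc3ccccc3)C2)c1Cl` keeps all of compound 2 except for one group, with benzyl in place of phenyl on a saturated ring carbon. Among the measured compounds shown here, no measured pair of compounds shows what a change of this kind does, so the expectation is a cautious one: no step beyond the scatter, in either direction, in this assay. The estimated step is a 1.2-fold lower number from compound 2 to compound 3 (0.08 log units; within the scatter). Compound 3 is expected at about 110000 nM, with an estimated range from 45000 nM to 260000 nM.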

Compound 3, half-maximal inhibitory concentration: 88000 nM
Compound 3: the middle estimate sits 1.3-fold (0.10 log units) above what was measured; low and high end bracket the measured number.
By their numbers in this assay, from the lowest: compounds 1, 3 and 2 (each within the scatter of the next).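

In this assay, replacing phenyl with benzyl on this saturated ring carbon gives a 1.5-fold lower number from compound 2 to compound 3 (0.18 log units; within the scatter). Among these compounds, this is the first measured pair of compounds that differ in only one place, and it shows that this assay does not separate these two groups at this position. Nothing measured independently bears on this result, so it comes without an explanation.

The two groups are closely alike, each carrying one six-membered aromatic ring of carbon only and no hydrogen-bond donors or acceptors, so this pair tests only a narrow change. The compounds shown leave open whether a longer chain such as phenylethyl, or a different kind of group such as an amine or a carboxylic acid, on this ring carbon would give a step beyond the scatter.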